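A Heavier Aryl Group on the Urea Nitrogen

The compounds below may be only part of what the source reports. "The series", "measured", "known", "first", "only" and "open" are said of these compounds alone.

Compound 1 `COc1nc(C)cc(SC)c1NC(=O)N(Cc1ccc(Oc2ccc(F)cc2)cc1)C1CCCCCC1` is the stronger of the two measured compounds: in an assay for inhibition of acyl-CoA:cholesterol acyltransferase (Oryctolagus cuniculus), using microsomes (a lower number here means a stronger inhibitor, a higher number a weaker inhibitor), compound 1 gives 29 nM. For the measured compounds named here, its only measured neighbour, compound 2 `CSc1cc(C)nc(S(C)(=O)=O)c1NC(=O)N(Cc1ccc(Oc2ccc(F)cc2)cc1)C1CCCCCC1`, carries a methylsulfonyl in place of methoxy on an aromatic carbon, and in this assay compound 2 gives 78 nM, so that a 2.7-fold higher number from compound 1 to compound 2 (0.43 log units; beyond the scatter). Compound 3 `Cc1cc(S(C)(=O)=O)c(NC(=O)N(Cc2ccc(Oc3ccc(F)cc3)cc2)C2CCCCCC2)c(Cl)n1` has not yet been measured. Against compound 1 it differs by a group of 12 heavy atoms (7 carbon, 1 nitrogen, 2 oxygen, 1 sulfur, 1 chlorine; one six-membered aromatic ring with 1 hetero atom) in place of a group of 11 heavy atoms (8 carbon, 1 nitrogen, 1 oxygen, 1 sulfur; one six-membered aromatic ring with 1 hetero atom), on an amide-type nitrogen; the incoming group again carries a methylsulfonyl and in addition a chlorine. Going by the values given here, the one measured step that bears on this is the one from compound 1 to compound 2, a modest loss; for the added chlorine no comparison exists. A modest loss is therefore expected, a 2.8-fold higher number from compound 1 to compound 3 (0.44 log units; beyond the scatter). For compound 3 the estimate in this assay is 80 nM, with a range from 25 nM to 250 nM.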

Compound 3, half-maximal inhibitory concentration: 30 nM
Compound 3: middle estimate off by 2.7-fold (0.43 log units), on the high side; the range from low to high includes it.
By their numbers in this assay, from the lowest: compounds 1 and 3 (each within the scatter of the next); then compound 2.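

Exchanging the aryl group on the amide-type nitrogen for a heavier one, carrying a methylsulfonyl and a chlorine, still gives an inhibitor on a par with compound 1 in this assay (a 1.0-fold higher number from compound 1 to compound 3 (0.01 log units; within the scatter)). A methylsulfonyl on this ring therefore does not always come with the modest loss seen earlier (a 2.7-fold higher number from compound 1 to compound 2 (0.43 log units; beyond the scatter)): compound 3 carries one too, yet its number stays within the scatter of that of compound 1. Nothing measured here explains why the two steps differ.

As far as these compounds go, compound 3 brings in the methylsulfonyl and the chlorine together, so the share of each in this result stays open. Also open, from the compounds shown here alone, is how the ring would fare with an amine or a carboxylic acid in place of the chlorine.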